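The source may hold more compounds than are shown below. What is called first, only, known or untested is meant among the compounds shown, and "the series" means these compounds.

Measured compounds:
compound 1 `O=C(O)/C(S)=C/c1c[nH]c2ccc(I)cc12` — 90 nM
compound 2 `O=C(O)/C(S)=C/c1c[nH]c2cccc(Br)c12` — 100 nM

Of the compounds shown here, two have been measured in an assay on isolated protein for inhibition of Calpain-1 catalytic subunit (Sus scrofa); a higher number here means a weaker inhibitor, a lower number a stronger inhibitor. Compound 1 `O=C(O)/C(S)=C/c1c[nH]c2ccc(I)cc12` gives 90 nM, and compound 2 `O=C(O)/C(S)=C/c1c[nH]c2cccc(Br)c12` gives 100 nM. Compound 1 holds the lowest of the two numbers, but its nearest neighbour, compound 2, sits within the scatter of it, so no order between the two can be drawn. Within the data shown here, no step between compounds that differ in a single place has been recorded.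

The unmeasured compound 3 `O=C(O)/C(S)=C/c1c[nH]c2ccc(F)cc12` differs from compound 1 by fluoro in place of iodo on an aromatic carbon. Among the measured compounds shown here, with no measured step of this kind among the two compounds, the size of the change can only be expected, not derived. In this assay the exchange of iodo for fluoro at this place is expected to weaken inhibition modestly, a step upward that may or may not clear the scatter. Compound 3 is therefore expected to give 250 nM, in a range from 80 nM to 800 nM. That would correspond to an expected step of a 2.8-fold higher number from compound 1 to compound 3 (0.44 log units; beyond the scatter).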

Compound 3, half-maximal inhibitory concentration: 930 nM
Beside the measured number, compound 3's estimate is 3.7-fold (0.57 log units) below it; the measured number lies above the stated range.
By their numbers in this assay, from the lowest: compounds 1 and 2 (each within the scatter of the next); then compound 3.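

In this assay, among these compounds, the exchange of iodo for fluoro on this aromatic carbon gives a 10-fold higher number from compound 1 to compound 3 (1.01 log units; beyond the scatter), the first single-place step, and it lies well beyond the scatter. The position is therefore not indifferent to which halogen it carries, although each group counts one heavy atom, with no hydrogen-bond donor or acceptor and no net charge. Nothing measured here explains why the step is so large.

The compounds shown leave open whether bromo or chloro at this same place would give a number nearer that of compound 1 or that of compound 3, and whether a methyl or methoxy group there would keep the lower number. They also leave open whether the same exchange at the place that carries bromo in compound 2 would give a step of similar size.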